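A few compounds are considered here, and "the series" means these few. Any claim that something is new, unique, unknown or untested is made for them only; others in the source may bear on it.

Working notes on the series. Compound 1 `O=C(O)CC/C=C\CO[C@H]1[C@@H](OCc2ccc(-c3ccccc3)cc2)CC[C@@H]1N1CCCCC1` gives in a functional assay for antagonist activity at thromboxane A2 receptor (Rattus norvegicus) (on this read-out higher numbers stand for weaker binding and lower numbers for tighter binding), 31.6 nM; 50.1 nM (2 entries); its repeat entries, (the several entries of compound 1 in this assay, 31.6 nM; 50.1 nM (2 entries)), sit close together. Among the compounds with values here, compound 2 `NC(=O)Cc1ccccc1-c1ccc(COC2CC[C@H](N3CCCCCC3)[C@H]2OC/C=C\CCC(=O)O)cc1` gives in this assay 158 nM, the only number available for it; a further entry carries no single number. Within the data shown here, compound 1 and compound 2 differ in more than one place, so their values are noted side by side and no step is drawn between them. Compound 3 `O=C(O)CC/C=C\CO[C@H]1C(OCc2ccc(-c3ccccc3CO)cc2)CC[C@@H]1N1CCCCCC1` differs from compound 2 by hydroxy in place of carbamoyl on a saturated chain carbon bound to an aromatic carbon. Among the measured compounds shown here, no single-change step between measured compounds exists to calibrate this, so the expected shift is a 1.1-fold lower number from compound 2 to compound 3 (0.02 log units; within the scatter), within the scatter and of no settled direction. Compound 3 is expected at 150 nM, range 50 nM to 450 nM.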

Compound 3, dissociation constant: 6.31 nM
For compound 3 the middle estimate is 24-fold (1.38 log units) above the measured one; the whole stated range lies above it.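

Hydroxy in place of carbamoyl on a saturated chain carbon bound to an aromatic carbon gives a 25-fold lower number from compound 2 to compound 3 (1.40 log units; beyond the scatter) in this assay, so the result at this position depends strongly on the group it carries. The step stands well clear of the agreement between repeat measurements of a single compound: the several entries of compound 1 in this assay, 31.6 nM; 50.1 nM (2 entries)

This single step does not settle whether the lower number comes from the presence of hydroxy or the loss of carbamoyl, and it gives no cause. A methoxy group, an amine or a carboxylic acid on the same carbon would help separate these readings.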